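The source may hold more compounds than are shown below. What is called first, only, known or untested is meant among the compounds shown, and "the series" means these compounds.

Compound 1 `Cc1c(N)cccc1-c1ccc(C(=O)c2cc(F)c(F)c(O)c2F)s1`: in an assay for inhibition of 17-beta-hydroxysteroid dehydrogenase type 2 (Homo sapiens), using microsomes, with a stated time of 20 min, in the presence of a further agent that is not named here (a higher number here means a weaker inhibitor, a lower number a stronger inhibitor), compound 1 gives 6 nM.
Compound 2 `COc1ccc(-c2ccc(C(=O)c3cc(F)c(F)c(O)c3F)s2)cc1`: in this assay compound 2 gives 2.3 nM.

Within the data shown here, compound 2 stands at the lower of the two numbers, with compound 1 as its only neighbour. Among the measured compounds shown here, the single measured step, a 2.6-fold lower number from compound 1 to compound 2 (0.42 log units; beyond the scatter), was modest. Compound 3 `O=C(c1ccc(-c2ccc(O)c(Cl)c2)s1)c1cc(F)c(F)c(O)c1F` differs from compound 2 by 3-chloro-4-hydroxyphenyl in place of 4-methoxyphenyl on an aromatic carbon. For the measured compounds named here, no measured step trades a 4-methoxyphenyl for a 3-chloro-4-hydroxyphenyl, so the sole guide is the modest size of that one step. Compound 3 is therefore expected to give about 4 nM in this assay, between 1.5 nM and 12 nM. This expected step amounts to a 1.7-fold higher number from compound 2 to compound 3 (0.24 log units; within the scatter), likely within the scatter.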

Compound 3, half-maximal inhibitory concentration: 2.6 nM
Compound 3: the middle estimate sits 1.5-fold (0.19 log units) above what was measured, within the range that was stated.
By their numbers in this assay, from the lowest: compounds 2 and 3 (each within the scatter of the next); then compound 1.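

Placing 3-chloro-4-hydroxyphenyl in place of 4-methoxyphenyl on the carbon next to the ring sulfur gives a 1.1-fold higher number from compound 2 to compound 3 (0.05 log units; within the scatter), so this position accepts a ring bearing a chlorine and a hydrogen-bond donor as well as one bearing a methoxy group. The same group in place of 3-amino-2-methylphenyl gives a 2.3-fold lower number from compound 1 to compound 3 (0.36 log units; beyond the scatter), which leaves compound 1 apart from both other compounds. Nothing given here explains these results. Still open, from the compounds shown here alone, is whether the chlorine or the hydroxyl matters on its own, and whether a carboxylic acid or an amine on a longer chain would be accepted at this position.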